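The source may report more compounds than this note shows. Statements on the series, on what has been measured and on what is new or still open speak of the compounds shown alone.

Three compounds sharing one core have been examined in a functional assay on SMMC-7721 cells (Homo sapiens) for inhibition, read by MTT assay, with a stated time of 48 h; on this read-out higher numbers stand for weaker inhibition and lower numbers for stronger inhibition. Compound 1 `O=C(Nc1ccncc1)Nc1cc(-c2cccnc2)cc(C(F)(F)F)c1` has the entry "not determined" (no result reported) there. Compound 2 `COc1ccc(-c2cc(NC(=O)Nc3ccncc3)cc(C(F)(F)F)c2)cn1` gives > 300000 nM, which is a limit of the assay and not a number. Within the data shown here, compound 3 `O=C(Nc1cc(-c2cccnc2)cc(C(F)(F)F)c1)Nc1nccs1` reads 68200 nM, the only true number among the three, so its standing cannot yet be ranked against a measured neighbour.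

Compound 4 `COc1ccc(-c2cc(NC(=O)Nc3nccs3)cc(C(F)(F)F)c2)cn1` departs from compound 3 in one place: methoxy in place of hydrogen on an aromatic carbon. This puts methoxy in place of hydrogen on an aromatic carbon, next to the ring nitrogen and para to a large group, turning pyridin-3-yl into 6-methoxypyridin-3-yl. Among the measured compounds shown here, no measured pair shows this change in this assay, as compound 1 has no value to set against compound 2. The 6-methoxypyridin-3-yl group also sits on compound 2, whose reading of > 300000 nM is a limit. On this slim basis, no step beyond the usual scatter is expected in this assay, with the risk leaning towards weaker inhibition. The expected change is a 1.3-fold higher number from compound 3 to compound 4 (0.12 log units; within the scatter). Compound 4 is estimated at 90000 nM, with an expected range from 30000 nM to 300000 nM.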

Compound 4, half-maximal inhibitory concentration: 36200 nM
Compound 4: the middle estimate sits 2.5-fold (0.40 log units) above what was measured; low and high end bracket the measured number.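

Methoxy in place of hydrogen on an aromatic carbon, next to the ring nitrogen and para to a large group, now has a measured pair in this assay, and it gives a 1.9-fold lower number from compound 3 to compound 4 (0.28 log units; within the scatter), so the pyridin-3-yl to 6-methoxypyridin-3-yl change leaves the number unmoved beyond the scatter while the 1,3-thiazol-2-yl group is in place. Among these compounds, with the 6-methoxypyridin-3-yl group held fixed, the other end of the molecule yields the first step beyond the scatter, 1,3-thiazol-2-yl in place of pyridin-4-yl on an amide-type nitrogen: an at least 8.2-fold lower number from compound 2 to compound 4 (0.91 log units; beyond the scatter). As far as these compounds go, the true size of that step stays unknown because compound 2 stands at a limit of the assay and not at a number: the limit of > 300000 nM in this assay, at which 1 of the 4 values shown sits.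

Compound 1 has no reported result, so the same methoxy change cannot be read with the pyridin-4-yl group in place. From the compounds shown here alone, whether an amine, a hydroxyl or a longer ethoxy chain at the same place on the ring would move the number beyond the scatter also stays open.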